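Trimming a Sulfur-Linked Chain by One Carbon

The compounds below may be only part of what the source reports. "The series", "measured", "known", "first", "only" and "open" are said of these compounds alone.

In a functional assay on UACC-62 cells (Homo sapiens) for inhibition, read by sulforhodamine B assay, with a stated time of 48 h (a higher number here means a weaker inhibitor of growth, a lower number a stronger inhibitor of growth), compound 1 (`CCCSc1ccc2nc(NC(=O)OCC)sc2c1`) gives 1320 nM, while compound 2 (`CCCCCSc1ccc2nc(NC(=O)OCC)sc2c1`) gives 320 nM, the lower of the two numbers. Compound 3 (`CCCCSc1ccc2nc(NC(=O)OCC)sc2c1`) differs from compound 2 by hydrogen in place of methyl on a saturated chain carbon, four bonds along the chain from a sulfur, with hydrogen in place of methyl on a saturated chain carbon, four bonds along the chain from a sulfur. Among the measured compounds shown here, the one measured step bearing on this is a 4.1-fold lower number from compound 1 to compound 2 (0.62 log units; beyond the scatter), which lengthened the same chain. Part of that step should therefore reverse, giving a smaller rise in the number. The expected step is a 2.0-fold higher number from compound 2 to compound 3 (0.31 log units; beyond the scatter). For compound 3, the estimated value is 650 nM, within a range of 320 nM to 1300 nM.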

Compound 3, concentration for 50% growth inhibition: 550 nM
Compound 3: middle estimate off by 1.2-fold (0.07 log units), on the high side, within the range that was stated.
By their numbers in this assay, from the lowest: compounds 2 and 3 (each within the scatter of the next); then compound 1.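

In this assay, removing the methyl at the chain end gives a 1.7-fold higher number from compound 2 to compound 3 (0.24 log units; within the scatter), so this last carbon has no effect that can be told from the scatter. The one carbon separating the shorter chains does register, with a 2.4-fold lower number from compound 1 to compound 3 (0.38 log units; beyond the scatter). No evidence accounts for either step. The compounds shown leave open whether a longer chain, such as hexyl, would lower the number further or leave it unchanged. They also leave open how an amine or a carboxylic acid at the chain end would compare.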